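Swapping a pentyl chain for a methylcyclohexenyl ring

A few compounds are considered here, and "the series" means these few. Any claim that something is new, unique, unknown or untested is made for them only; others in the source may bear on it.

Compound 1 `CCCCCc1nc(C(F)(F)F)ccc1CNC(=O)C(C)c1ccc(NS(C)(=O)=O)c(F)c1`: 1 nM
Compound 2 `C[C@H](C(=O)NCc1ccc(C(F)(F)F)nc1C1CCC(C)(C)CC1)c1ccc(NS(C)(=O)=O)c(F)c1`: 0.3 nM

Both compounds share one core and were tested in an assay on CHO cells for antagonist activity at transient receptor potential cation channel subfamily V member 1 (Homo sapiens), read by FLIPR and calcium flux; on this read-out lower numbers stand for stronger inhibition and higher numbers for weaker inhibition. Compound 1 gives 1 nM, which is the higher of the two numbers; compound 2 gives 0.3 nM, a gap beyond the usual scatter, so compound 2 is the stronger inhibitor of the pair. The two differ only in the group that sits on the six-membered aromatic ring with one nitrogen: a pentyl chain in compound 1, a saturated carbon ring in compound 2.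

Compound 3 `CC(C(=O)NCc1ccc(C(F)(F)F)nc1C1=C[C@H](C)CCC1)c1ccc(NS(C)(=O)=O)c(F)c1` has not yet been measured. It differs from compound 1 as follows: 3-methylcyclohex-1-en-1-yl in place of pentyl on an aromatic carbon. Compound 2 shows that a carbon ring in this position is compatible with very strong inhibition, and compound 3 also carries a carbon ring there, though one with a double bond and a single methyl group. The step from compound 1 to compound 3 is expected to be small, a 1.7-fold lower number from compound 1 to compound 3 (0.22 log units; within the scatter), pointing downward or staying within the scatter. Compound 3 is therefore estimated at 0.6 nM, with a range from 0.2 nM to 2 nM.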

Compound 3, inhibition constant: 0.1 nM
Estimate against measurement, compound 3: 6.0-fold (0.78 log units) above, outside the stated range (below it).
By their numbers in this assay, from the lowest: compound 3; then compound 2; then compound 1.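

In this assay, placing 3-methylcyclohex-1-en-1-yl in place of pentyl on this aromatic carbon, next to the ring nitrogen, gives a 10-fold lower number from compound 1 to compound 3 (1.00 log units; beyond the scatter). This shows that the position does more than accept a ring carrying a double bond and a methyl group: exchanging the open pentyl chain for this ring strengthens inhibition by a margin beyond the usual scatter, even though compound 1 was already a strong inhibitor. No measurement available here explains why this exchange has such an effect.

The ring, its double bond, its methyl group and the defined stereocentre all enter together in this single step. This step cannot separate them, and the opposite arrangement at that stereocentre remains unmeasured. As far as these compounds go, it also remains open whether an unsubstituted cyclohexyl ring, a phenyl ring or an amine on the same aromatic carbon would give inhibition as strong as that of compound 3.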